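The compounds below may be only part of what the source reports. "The series", "measured", "known", "first", "only" and "open" are said of these compounds alone.

Of the compounds shown here, three built on one shared core have been measured. Compound 1 `COC(=O)c1cc(-c2cccc(NC(=O)c3ccc(/C=C/C(=O)c4cc(OC)c(OC)c(OC)c4)cc3)c2)on1` in an ADME assay on Vero cells (Chlorocebus sabaeus) for cytotoxicity, read by MTT assay, with a stated time of 72 h (a higher number here means that more compound is tolerated, a lower number that less compound is tolerated), gives > 50 ug/mL, which is a limit of the assay rather than a number. Compound 2 `COC(=O)c1cc(-c2cccc(NC(=O)c3ccc(/C=C/C(=O)c4ccc(OC)c(OC)c4)cc3)c2)on1` in this assay gives > 50 ug/mL, again only a limit. Compound 3 `COC(=O)c1cc(-c2cccc(NC(=O)c3ccc(/C=C/C(=O)c4ccc(Cl)cc4Cl)cc3)c2)on1` in this assay gives > 40 ug/mL, also a limit. With every value a limit, the steps between these compounds cannot be sized: a step that the two limits leave unreadable from compound 1 to compound 2, a step that the two limits leave unreadable from compound 1 to compound 3 and a step that the two limits leave unreadable from compound 2 to compound 3. Compound 3 stands at the limit of > 40 ug/mL in this assay, at which 1 of the 3 values shown sits. The two other values sit at the limit of > 50 ug/mL in this assay, at which 2 of the 3 values shown sit.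

Compound 4 `COC(=O)c1cc(-c2cccc(NC(=O)c3ccc(/C=C/C(=O)c4cccc([N+](=O)[O-])c4)cc3)c2)on1` differs from compound 3 in a single place: 3-nitrophenyl in place of 2,4-dichlorophenyl on a carbonyl carbon. For the measured compounds named here, none of the measured steps offers a readable size for comparison, so the only guide is that each compound here was tolerated up to the highest concentration tested. The expectation is therefore that compound 4 produces no readable step beyond the scatter, a step that the limit leaves unreadable from compound 3 to compound 4. The estimate for compound 4 in this assay is 60 ug/mL, within a range from 35 ug/mL to 150 ug/mL, and it is expected that the assay will most likely again report a limit rather than a number.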

Compound 4, half-maximal cytotoxic concentration: > 40 ug/mL
Compound 4 ended at the assay's limit; the forecaster's own chance of this, stated with the estimate: 80%; the middle value lies beyond the limit too.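

In this assay compound 4 gives > 40 ug/mL, which is a limit of the assay and not a number. With all four values being limits, the steps from compound 1, compound 2 and compound 3 to compound 4 cannot be read. The compounds shown leave open how much of each compound the cells tolerate, and whether the group on the carbonyl carbon changes that at all.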